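Trimethoxyphenyl in Place of Phenylethenyl on the Shared Core

The compounds below may be only part of what the source reports. "The series", "measured", "known", "first", "only" and "open" are said of these compounds alone.

The compounds are compared in a functional assay on SNB-75 cells (Homo sapiens) for antiproliferative activity, with a stated time of 48 h; a lower number here means a stronger inhibitor of growth, a higher number a weaker inhibitor of growth. Compound 1 `Cc1cc(O)c(C2=NN(c3ccc(S(N)(=O)=O)cc3)C(c3ccccc3Cl)C2)cc1Cl` gives 2230 nM in this assay. Compound 2 `Cc1cc(O)c(C2=NN(c3ccc(S(N)(=O)=O)cc3)C(/C=C/c3ccccc3)C2)cc1Cl` gives 3390 nM in this assay. The two are joined by a single change, and the step of a 1.5-fold higher number from compound 1 to compound 2 (0.18 log units; within the scatter) describes it. Among the compounds with values here, of the two numbers so far, compound 2 carries the higher one, with compound 1 nearest to it; since the two lie within the scatter of each other, no order between them is claimed.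

Compound 3 `COc1ccc(C2CC(c3cc(Cl)c(C)cc3O)=NN2c2ccc(S(N)(=O)=O)cc2)c(OC)c1OC` has not yet been measured. It differs from compound 2 in one place: 2,3,4-trimethoxyphenyl in place of 2-phenylethenyl on a saturated ring carbon. Within the data shown here, the only measured step that alters the same saturated ring carbon is a 1.5-fold higher number from compound 1 to compound 2 (0.18 log units; within the scatter), and that step stayed within the scatter. Among the measured compounds shown here, no measured step introduces a trimethoxyphenyl group, so nothing further bears on this change. One therefore expects, in this assay, a step from compound 2 to compound 3 of small size and uncertain direction, namely a 1.3-fold lower number from compound 2 to compound 3 (0.12 log units; within the scatter). Compound 3 is estimated at 2600 nM, with a range from 800 nM to 8500 nM.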

Compound 3, concentration for 50% growth inhibition: 2450 nM
Compound 3: middle estimate off by 1.1-fold (0.03 log units), on the high side; the measured number falls inside the stated range.
By their numbers in this assay, from the lowest: compounds 1, 3 and 2 (each within the scatter of the next).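

Read in this assay, the step to 2,3,4-trimethoxyphenyl (a 1.4-fold lower number from compound 2 to compound 3 (0.14 log units; within the scatter)) and the step that replaces 2-chlorophenyl with the same group (a 1.1-fold higher number from compound 1 to compound 3 (0.04 log units; within the scatter)) both stay within the scatter. The saturated ring carbon next to the ring nitrogen has therefore now carried three different groups in compound 1, compound 2 and compound 3 with no step beyond the scatter, even though the entering group has 12 heavy atoms and 3 hydrogen-bond acceptors, while the 2-phenylethenyl group it replaces has 8 heavy atoms and no hydrogen-bond acceptors. Nothing available explains why these numbers stay so close.

From the compounds shown here alone, each of the three groups contains a six-membered aromatic ring of carbon only, so it remains open whether a group without such a ring, such as an amine, a carboxylic acid or a longer alkyl chain, would give a step beyond the scatter at this carbon. Going by these compounds, it is also open whether all three methoxy groups are needed for compound 3 to stay this close to compound 1 and compound 2, since a phenyl ring with a single methoxy group does not appear among them.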